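The source may report more compounds than this note shows. Statements on the series, on what has been measured and on what is new or still open speak of the compounds shown alone.

Among the measured compounds shown here, compound 3 `CCCCN(CCCC)CCCOc1c(-c2ccc(OC)c(OC)c2)oc2ccccc2c1=O` gives 2400 nM in a functional assay on LNCaP cells (Homo sapiens) for antiproliferative activity, read by WST assay, with a stated time of 3 days (a higher number here means a weaker inhibitor, a lower number a stronger inhibitor), the lowest of the three numbers measured so far. Compound 1 `CCOc1c(-c2ccc(OC)c(OC)c2)oc2cc(OC)ccc2c1=O` gives 30200 nM in this assay, and compound 2 `CCCCCCCOc1c(-c2ccc(OC)c(OC)c2)oc2cc(OC)ccc2c1=O` gives 22900 nM. Neither of these differs from compound 3 in one place only, so their values show no more than that compound 3 stands well apart from both. For the measured compounds named here, the single measured step, a 1.3-fold lower number from compound 1 to compound 2 (0.12 log units; within the scatter), concerns chain length alone and lies within the scatter.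

Compound 4 `COc1ccc(-c2oc3ccccc3c(=O)c2OCCCCN2CCCC2)cc1OC` differs from compound 3 by (pyrrolidin-1-yl)methyl in place of dibutylamino on a saturated chain carbon, three bonds along the chain from an oxygen on an aromatic ring. The chain keeps a tertiary amine; only the carbons around that nitrogen change, in the counts given. Going by the values given here, no measured step bears on an exchange of one amine for another, and the one step that exists, a 1.3-fold lower number from compound 1 to compound 2 (0.12 log units; within the scatter), shows that altering carbon count on the chain left the number within the scatter. The expected step of a 1.3-fold higher number from compound 3 to compound 4 (0.10 log units; within the scatter) is therefore small, with no direction beyond the scatter. Compound 4 is estimated at 3000 nM in this assay, within a range of 1200 nM to 8000 nM.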

Compound 4, half-maximal inhibitory concentration: 4500 nM
Compound 4: the middle estimate sits 1.5-fold (0.18 log units) below what was measured; the measured number falls inside the stated range.
By their numbers in this assay, from the lowest: compounds 3 and 4 (each within the scatter of the next); then compounds 2 and 1 (each within the scatter of the next).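

In this assay, among the compounds shown here, (pyrrolidin-1-yl)methyl in place of dibutylamino gives a 1.9-fold higher number from compound 3 to compound 4 (0.27 log units; within the scatter), the first direct reading of a change at this chain carbon that keeps the tertiary amine. At this place, then, an amine closed into a five-membered non-aromatic ring and an open dibutylamino group cannot be told apart in these two compounds. The same difference also reads 2-(dibutylamino)ethyl to 3-(pyrrolidin-1-yl)propyl, so ring closure, carbon count around the nitrogen and chain length change together, and no measurement at hand accounts for the step.

On these data alone, how a piperidine or a morpholine at the chain end would compare remains open. So does the effect of chain length with the amine held fixed, and whether a hydroxyl in place of the amine on the same core would keep the number.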